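The compounds below may be only part of what the source reports. "The series", "measured", "known", "first", "only" and "open" are said of these compounds alone.

Within the data shown here, in a toxicity assay on cells (Macrophage, Mus musculus, strain BALB/c) for cytotoxicity, read by MTT assay (a lower number here means a stronger inhibitor, a higher number a weaker inhibitor), compound 1 `COc1cc(O)cc(O)c1C(=O)/C=C/c1ccco1` gives 384000 nM and compound 2 `COc1cc(O)cc(O)c1C(=O)/C=C/c1ccc(Cl)cc1` gives 19000 nM as the lower of the two numbers measured so far. Compound 3 `COc1ccc(/C=C/C(=O)c2c(O)cc(O)cc2OC)cc1` keeps all of compound 2 except one group, with methoxy in place of chloro on an aromatic carbon, para to a large group, and methoxy in place of chloro on an aromatic carbon is the counted difference. Among the measured compounds shown here, only one measured step bears on this, a 20-fold lower number from compound 1 to compound 2 (1.31 log units; beyond the scatter) with 4-chlorophenyl in place of furan-2-yl, and that large step swapped a whole ring, whereas here the ring stays, so a much smaller step is expected in this assay this time. For the measured compounds named here, no measured compound carries methoxy on that ring, so the direction is uncertain, with a slight lean towards a higher number. The estimated step is a 1.6-fold higher number from compound 2 to compound 3 (0.20 log units; within the scatter) and no larger. For compound 3 the estimated value is 30000 nM with an expected range from 10000 nM to 90000 nM.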

Compound 3, half-maximal inhibitory concentration: 166000 nM
Estimate against measurement, compound 3: 5.5-fold (0.74 log units) below; measured number outside the range, above it.
By their numbers in this assay, from the lowest: compound 2; then compound 3; then compound 1.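

Chloro and methoxy are small groups, yet this single exchange on the aromatic ring, with the rest of the molecule unchanged, gives an 8.7-fold higher number from compound 2 to compound 3 (0.94 log units; beyond the scatter) in this assay. The earlier step replaced a whole ring, whereas this one shows that the number also responds to the group at this one place on the ring, and that a change of this size can lie beyond the scatter. The exchange adds one heavy atom and one hydrogen-bond acceptor, but nothing available explains why the number rises.

Only chloro and methoxy are shown at this place, so it stays open how a fluoro, a methyl or an amine there would read in this assay. On these data alone, whether the same exchange gives a step of similar size elsewhere on the ring also remains open.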